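Pyridinium ketone series: solubility, ethyl to benzyl step

The source may hold more compounds than are shown below. What is called first, only, known or untested is meant among the compounds shown, and "the series" means these compounds.

Measured so far:
- compound 1, `COc1cc2cc(C=C3CC[N+](C)(Cc4ccccc4)CC3)sc2cc1OC`: 1000 ug/mL
- compound 2, `CC[n+]1ccc(CCC(=O)c2cc3cc(OC)c(OC)cc3s2)cc1`: 25000 ug/mL

In a physicochemical assay for solubility (a lower number here means a less soluble compound, a higher number a more soluble compound), compound 2 gives 25000 ug/mL and stands highest of the two numbers recorded. Compound 1 sits well lower in this assay at 1000 ug/mL; the gap between the two lies beyond the scatter, but the two structures differ in several places at once, so no single change can be read from that pair.

Compound 3 is `COc1cc2cc(C(=O)CCc3cc[n+](Cc4ccccc4)cc3)sc2cc1OC` and has not yet been measured in this assay. It departs from compound 2 in one place: phenyl in place of methyl on a saturated chain carbon bound to an aromatic nitrogen. Going by the values given here, no measured pair isolates this change, so the size of the step rests on expectation only. Adding a phenyl ring to a compound that carries a positive charge usually costs solubility; the step from ethyl to benzyl is expected to move the number downward, by an amount that should exceed the scatter, while keeping compound 3 on the soluble side.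

The estimate for compound 3 in this assay is 5000 ug/mL, with a range from 1500 ug/mL to 15000 ug/mL. This corresponds to an expected step of a 5.0-fold lower number from compound 2 to compound 3 (0.70 log units; beyond the scatter).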

Compound 3, solubility: 2000 ug/mL
Compound 3: the middle estimate sits 2.5-fold (0.40 log units) above what was measured; the measured number falls inside the stated range.
By their numbers in this assay, from the lowest: compounds 1 and 3 (each within the scatter of the next); then compound 2.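

In this assay, going by these compounds alone, the change of phenyl in place of methyl on a saturated chain carbon bound to an aromatic nitrogen gives the first reading of a single change: a 13-fold lower number from compound 2 to compound 3 (1.10 log units; beyond the scatter) is a large step. Within the data shown here, the earlier pair differed in several places at once, so only this pair shows that the number responds to the group at this place, and that the ethyl to benzyl change moves it downward. Even after this step, compound 3 gives 2000 ug/mL in this assay while keeping the ketone chain and the shared core of compound 2 unchanged.

Still open, from the compounds shown here alone, is how much of the step follows the aromatic ring itself rather than the larger group as a whole, a question that a propyl or cyclohexylmethyl group at the same place, or a carboxylic acid or an amine on the phenyl ring, would bear on. No supporting measurement is available to explain the size or direction of this step.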